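Moving the Chlorine on a Phenyl Ring: Compound 2 to Compound 4

A few compounds are considered here, and "the series" means these few. Any claim that something is new, unique, unknown or untested is made for them only; others in the source may bear on it.

Measured compounds:
compound 1 `COc1ccc(-c2nc(C)oc2C(=O)N2CCN(c3cccc(Cl)c3)CC2)cc1O` — "not active" (no number reported)
compound 2 `Cc1ccc(C)c(N2CCN(C(=O)c3oc(C)nc3-c3ccc(Cl)cc3)CC2)c1` — "not active" (no number reported)
compound 3 `CCc1nc(-c2ccccc2F)c(C(=O)N2CCN(c3cccc(OC)c3)CC2)o1` — 607 nM

In a functional assay on HL-60 cells (Homo sapiens) for inhibition, read by MTT assay, with a stated time of 72 h (on this read-out higher numbers stand for weaker inhibition and lower numbers for stronger inhibition), compound 2 is reported as "not active" (no number reported), with no number given for it. Compound 1 stands in the same position: in this assay compound 1 is also "not active" (no number reported), again without a number. Only compound 3 comes with a figure: in this assay compound 3 gives 607 nM. Compound 3 differs from compound 2 in several places at once, so nothing can be drawn from their two values about any single change.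

Compound 4 `Cc1ccc(C)c(N2CCN(C(=O)c3oc(C)nc3-c3ccccc3Cl)CC2)c1` has not been measured. It differs from compound 2 in one spot: 2-chlorophenyl in place of 4-chlorophenyl on an aromatic carbon. The two compounds share every atom; only the point at which the chlorine sits on the phenyl ring moves.

Going by the values given here, no measured pair in this set shows what such a move does, and compound 2 itself has no number, so the size of the step cannot be judged from the data. With compound 2 reported as "not active" (no number reported), compound 4 is expected most likely to stay weak, with some chance of a measurable value. For compound 4 in this assay the estimate is 15000 nM, within a range from 1500 nM to 100000 nM.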

Compound 4, half-maximal inhibitory concentration: > 1000 nM
Compound 4: only a limit was reported; the forecaster's own chance of this, stated with the estimate: 65%; the middle value is on the limit's open side.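

In this assay compound 4 gives > 1000 nM, which is a limit and not a number. Going by these compounds alone, compound 2 is reported as "not active" (no number reported), and no step between compound 2 and compound 4 can be read from these two entries. The compounds shown leave open what changing 4-chlorophenyl to 2-chlorophenyl does to inhibition.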